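Swapping an oxadiazole for an ethoxycarbamoyl on a shared core

This account rests on a few compounds, and the source may have more. Where it says the series, first, only, none or still open, it means among the compounds named here.

Measured compounds:
- Compound 1, `CC(CCOc1ccc(-c2noc(C(C)(C)C)n2)cc1)CCN1CCN(c2ccnc(N)c2)C1=O`: 55000 nM
- Compound 2, `CCO/N=C/c1ccc(OCCCCCN2CCN(c3ccnc(N)c3)C2=O)cc1`: 59000 nM
- Compound 3, `CCCc1nc(-c2ccc(OCCC(C)CCN3CCN(c4ccnc(N)c4)C3=O)cc2)no1`: > 100000 nM (a limit of the assay)

Of the compounds shown here, three sharing the same core have been tested in an ADME assay on RD cells (Homo sapiens) for cytotoxicity, read by MTT assay, with a stated time of 24 h; a higher number here means that more compound is tolerated, a lower number that less compound is tolerated. Compound 1 gives 55000 nM. Compound 2 gives 59000 nM. Compound 3 gives no number, only a limit of the assay, > 100000 nM. So compound 3 stands at the ceiling of what this assay reports, while the other two sit below it.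

Among the measured compounds shown here, only one step between measured compounds differs in a single place: an at least 1.8-fold higher number from compound 1 to compound 3 (0.25 log units; that floor lies within the scatter). Its floor lies inside the usual scatter, so it says little more than that compound 3 is tolerated at least as well as compound 1.

Compound 4, `CCONC(=O)c1ccc(OCCC(C)CCN2CCN(c3ccnc(N)c3)C2=O)cc1`, is not yet measured. It differs from compound 3 in one place: ethoxycarbamoyl in place of 5-propyl-1,2,4-oxadiazol-3-yl on an aromatic carbon. For the measured compounds named here, no measured step covers this change, and the single step available, from compound 1 to compound 3, touched a different group. The nearest point of comparison is that compound 2, whose aromatic ring also carries an ethoxy-bearing group, gives 59000 nM.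

With nothing pointing to a step beyond the scatter in either direction, compound 4 is expected to give about 80000 nM in this assay, in a range of 35000 nM to 180000 nM; the estimated step is an at least 1.2-fold lower number from compound 3 to compound 4 (0.09 log units; that floor lies within the scatter).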

Compound 4, half-maximal cytotoxic concentration: > 100000 nM
Compound 4 gave a limit, no number (the forecaster's own chance of this, stated with the estimate: 40%); at least 1.2-fold (0.09 log units) between middle value and limit.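

In this assay, among the compounds shown here, the compounds with this chain had so far carried only 1,2,4-oxadiazole rings on the aromatic carbon para to a large group. Compound 4 shows that ethoxycarbamoyl, which has no ring and brings a hydrogen-bond donor, can sit at this position while the read-out still reaches a limit of the assay. From the compounds shown here alone, replacing the 5-(tert-butyl)-1,2,4-oxadiazol-3-yl group gives an at least 1.8-fold higher number from compound 1 to compound 4 (0.25 log units; that floor lies within the scatter), so this change brings no visible loss of tolerance, though the size of any gain stays unknown. The step that replaces the 5-propyl-1,2,4-oxadiazol-3-yl group cannot be read, because both compounds sit at the same limit: the limit of > 100000 nM in this assay, at which 2 of the 4 values shown sit.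

Going by these compounds, how far compound 3 and compound 4 would lie beyond that limit remains open, so any real difference between the ring and the open group stays hidden. Also open, on these data alone, is whether a carboxylic acid or an amine on this aromatic carbon would bring the read-out down to a measurable number.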